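The compounds below may be only part of what the source reports. "The series", "measured", "known", "first", "only" and "open" are said of these compounds alone.

For the measured compounds named here, the series shares a diaryl ether core carrying an anilino group, and the three measured members are compound 1 `Cc1cccc(C)c1Oc1cc(Nc2ccc(C#N)cc2)[nH]c(=O)c1`, compound 2 `COc1cc(Oc2c(C)cccc2C)cc(Nc2ccc(C#N)cc2)n1` and compound 3 `COc1cc(Oc2c(C)cc(C)cc2C)cc(Nc2ccc([N+](=O)[O-])cc2)n1`. All were tested in an ADME assay on MT4 cells (Homo sapiens) for cytotoxicity, read by MTT assay, with a stated time of 5 days; a lower number here means that less compound is tolerated, a higher number that more compound is tolerated. In this assay compound 1 gives 36000 nM. Compound 2 gives 8500 nM in this assay. Compound 3 gives 7200 nM in this assay, the lowest of the three numbers, though its gap to compound 2 lies within the scatter and only its gap to compound 1 lies beyond it.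

The next member is compound 4 `COc1cc(Oc2c(C)cc(C)cc2C)cc(Nc2ccc(C#N)cc2)n1`, not yet measured in this assay. It differs from compound 3 in one place: cyano in place of nitro on an aromatic carbon. Going by the values given here, no directly comparable step among the measured compounds shows what this exchange does. The closest guide is compound 2, which also carries the cyano group and gives 8500 nM, a number within the scatter of compound 3. From compound 3 to compound 4 the step in this assay is therefore expected to be a 1.0-fold higher number from compound 3 to compound 4 (0.02 log units; within the scatter), that is, none beyond the scatter. Compound 4 is estimated to give 7500 nM in this assay, with a plausible range from 3000 nM to 18000 nM.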

Compound 4, half-maximal cytotoxic concentration: 29000 nM
The estimate for compound 4 lay 3.9-fold (0.59 log units) below the measured number; the measured number lies above the stated range.
By their numbers in this assay, from the lowest: compounds 3 and 2 (each within the scatter of the next); then compounds 4 and 1 (each within the scatter of the next).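

For the compounds shown here, on the aromatic carbon para to a large group, in this assay the exchange of 4-nitrophenyl for 4-cyanophenyl gives a 4.0-fold higher number from compound 3 to compound 4 (0.61 log units; beyond the scatter) and so provides the first direct reading of this change, which shows that the two groups are not interchangeable here and that more compound is tolerated with cyano in this pair. The methyl in place of hydrogen on an aromatic carbon gives a 3.4-fold higher number from compound 2 to compound 4 (0.53 log units; beyond the scatter) in the same assay, so a second single change leading to compound 4 also moves the number beyond the scatter and in the same direction, and the cyano group alone does not fix the tolerated concentration. Nothing among the data shown bears on the cause of either step.

From the compounds shown here alone, whether cyano in place of nitro gives a similar step on a compound without that added methyl remains open, so the two changes cannot yet be said to act independently of each other. Going by these compounds, it is also open how an amine or a carboxylic acid in place of cyano on the same aromatic carbon would read in this assay and whether such groups would fall nearer compound 3 or compound 4.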